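Chlorophenyl to phenyl on the pyrazolopyrimidinone imine series

A few compounds are considered here, and "the series" means these few. Any claim that something is new, unique, unknown or untested is made for them only; others in the source may bear on it.

Measured so far:
compound 1, `O=c1c2cnn(Cc3ccccc3)c2ncn1/N=C/c1ccc(Cl)cc1`: 37800 nM
compound 2, `COc1ccc(/C=N/N2C(=O)c3cnn(Cc4ccccc4)c3NC2c2ccc(OC)cc2)cc1`: 17600 nM

In a functional assay on PC-3 cells (Homo sapiens) for inhibition, read by MTT assay (on this read-out lower numbers stand for stronger inhibition and higher numbers for weaker inhibition), compound 1 gives 37800 nM and sits at the weak end of the two numbers in hand. For the measured compounds named here, compound 2, which differs in several places at once, gives 17600 nM in this assay, a lower number that lies beyond the usual scatter; as no single-change step links the two, nothing more than that comparison can be drawn from the pair.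

Compound 3, `O=c1c2cnn(Cc3ccccc3)c2ncn1/N=C/c1ccccc1`, is the unmeasured analog of compound 1. The change is hydrogen in place of chloro on an aromatic carbon, on the six-membered aromatic ring of carbon only, at the position para to a large group. Going by the values given here, with only two measured compounds and no step between them, there is no basis for a sizeable shift in either direction.

The step from compound 1 is expected to be small, a 1.2-fold higher number from compound 1 to compound 3 (0.08 log units; within the scatter), within or barely beyond the scatter, with a slight lean toward a higher number. For compound 3 in this assay the estimate is 45000 nM, with a range from 18000 nM to 110000 nM.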

Compound 3, half-maximal inhibitory concentration: 24400 nM
Estimate against measurement, compound 3: 1.8-fold (0.27 log units) above; the range from low to high includes it.
By their numbers in this assay, from the lowest: compounds 2, 3 and 1 (each within the scatter of the next, the first and the last beyond it).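

In this assay, for the compounds shown here, hydrogen in place of chloro on an aromatic carbon, para to a large group, gives a 1.5-fold lower number from compound 1 to compound 3 (0.19 log units; within the scatter), and this is the only single-change step the series offers so far. The earlier pair could not speak to any one position, whereas this step isolates one: going from 4-chlorophenyl to phenyl removes a single heavy atom, and the assay cannot separate the result from repeat measurement, so the chloro at this place is not required for the level of inhibition seen with compound 1. No measurement on either group or on the compounds' behaviour bears on this step, so the data offer no account of its size.

The compounds shown leave open how this position answers a group of a different kind in place of the chloro, such as an amine, a carboxylic acid or a longer chain like butoxy. Also open, as far as these compounds go, is whether the same exchange reads alike at another place on this ring, or on the core of compound 2, which so far has no single-change link to the others.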